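Fluorosulfonyl on the Distal Ring of a Diaminotriazine Inhibitor

This account rests on a few compounds, and the source may have more. Where it says the series, first, only, none or still open, it means among the compounds named here.

Of the compounds shown here, three sharing one core have been tested in an assay on isolated protein for inhibition of Dihydrofolate reductase (Mus musculus); on this read-out lower numbers stand for lower potency and higher numbers for higher potency (the scale is a negative logarithm). Compound 1 `CC1(C)N=C(N)N=C(N)N1c1ccc(CCc2ccccc2)cc1` gives 7.89, the highest of the three numbers. Compound 2 `CC1(C)N=C(N)N=C(N)N1c1ccc(OCc2cccc(S(=O)(=O)F)c2)c(Cl)c1` gives 7.72, a number within the usual scatter of that of compound 1. Compound 3 `CC1(C)N=C(N)N=C(N)N1c1ccc(OCc2ccc(S(=O)(=O)F)c(Cl)c2)c(Cl)c1` gives 7.43, a number beyond the scatter below compound 1. No two of these differ in only one place, so no single step can be read from them.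

Compound 4 `CC1(C)N=C(N)N=C(N)N1c1ccc(CCc2ccc(S(=O)(=O)F)cc2)cc1` differs from compound 1 in one place: fluorosulfonyl in place of hydrogen on an aromatic carbon. The two compounds carrying fluorosulfonyl give numbers no higher than compound 1, so in this assay only a small step is expected, from compound 1 to compound 4 of a number 0.19 log units lower from compound 1 to compound 4 (within the scatter), not beyond the scatter. Compound 4 is therefore estimated at 7.7, between 7.1 and 8.3.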

Compound 4, logarithm of the reciprocal of the active concentration, log(1/C): 7.41
The estimate for compound 4 lay 0.29 log units above the measured number; the measured number falls inside the stated range.
By their numbers in this assay, from the lowest: compounds 4, 3, 2 and 1 (each within the scatter of the next, the first and the last beyond it).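

With this assay, the series now has its first step that can be read for a single change: fluorosulfonyl in place of hydrogen on an aromatic carbon, para to a large group, gives a number 0.48 log units lower from compound 1 to compound 4 (beyond the scatter). This shows that, on the scaffold of compound 1, this position does not take fluorosulfonyl without a modest loss. No available evidence accounts for this step.

From the compounds shown here alone, whether the loss belongs to fluorosulfonyl itself or to any substituent at this carbon remains open. An amine, a carboxylic acid or a methyl group at the same place would help to separate the two.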